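The compounds below may be only part of what the source reports. "The series", "measured", "known", "first", "only" and "open" are said of these compounds alone.

Compound 3 `Cc1cc(-c2nc(C(c3ccc(F)cc3)c3ccc(F)cc3)sc2CC(=O)O)cnc1N` gives 80% in an in vitro functional assay on HEK285-7 cells for antagonist activity at prostaglandin D2 receptor 2 (Homo sapiens), read by BRET and beta-arrestin recruitment (on this read-out higher numbers stand for larger maximal responses and lower numbers for smaller maximal responses), level with compound 2 `O=C(O)Cc1sc(C(c2ccc(F)cc2)c2ccc(F)cc2)nc1-c1ccnc(F)c1` at 80%, while compound 1 `Nc1cc(-c2nc(C(c3ccc(F)cc3)c3ccc(F)cc3)sc2CC(=O)O)cc(F)n1` sits lowest at 30%. The next step alters the aryl group on the shared core: 3-cyano-4-fluorophenyl in place of 6-amino-5-methylpyridin-3-yl on an aromatic carbon gives compound 4 `N#Cc1cc(-c2nc(C(c3ccc(F)cc3)c3ccc(F)cc3)sc2CC(=O)O)ccc1F`. Within the data shown here, three measured steps bear on this swap: a number 50 percentage points higher from compound 1 to compound 2 (beyond the scatter), a number 50 percentage points higher from compound 1 to compound 3 (beyond the scatter) and no change at the digits printed from compound 2 to compound 3 (within the scatter). Compound 2, which likewise lacks an amino group, gives 80%, and both large steps run away from compound 1 alone, so a change of the aryl ring need not move the maximal response. For compound 4 a step within the scatter is expected, a number 5 percentage points lower from compound 3 to compound 4 (within the scatter). The estimate for compound 4 is 75%, in a range from 50% to 95%.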

Compound 4, largest response reached (reported as efficacy), in percent of the reference or control that the assay uses: 80%
Compound 4: middle estimate off by 5 percentage points, on the low side; the range from low to high includes it.
By their numbers in this assay, from the lowest: compound 1; then compounds 2, 3 and 4 (each within the scatter of the next).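

In this assay, a ring of carbon only, bearing a nitrile and a fluorine, gives no change at the digits printed from compound 3 to compound 4 (within the scatter) and no change at the digits printed from compound 2 to compound 4 (within the scatter), so a ring nitrogen is not needed at this aromatic carbon to keep the maximal response. The same ring gives a number 50 percentage points higher from compound 1 to compound 4 (beyond the scatter), which leaves compound 1 as the only one of the four set apart from the others.

As far as these compounds go, whether a saturated ring such as piperidine on this aromatic carbon keeps the response stays open. No evidence on the origin of these steps is at hand.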